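A benzyl(methyl)amino group replaces 4-carbamoylpiperidin-1-yl

A few compounds are considered here, and "the series" means these few. Any claim that something is new, unique, unknown or untested is made for them only; others in the source may bear on it.

In an ADME assay on J774.1 cells (Mus musculus) for cytotoxicity, read by resazurin assay, with a stated time of 48 h (on this read-out higher numbers stand for weaker inhibition and lower numbers for stronger inhibition), three compounds sharing one core have been read so far. Among the compounds with values here, compound 3 `CCCCn1cc(C(=O)NCc2ccccc2)c(=O)c2cc(F)c(N3CCC(C(N)=O)CC3)cc21` gives 47000 nM, the only true number among them. Compound 1 `CCCCn1cc(C(=O)NCc2ccccc2)c(=O)c2cc(F)c(N(C)C)cc21` reads > 100000 nM, which is a limit of the assay. Compound 2 `CCCCn1cc(C(=O)NCc2ccccc2)c(=O)c2cc(F)c(-c3ccccc3)cc21` reads > 100000 nM, which is also a limit. Compound 3 therefore stands at the low-number, stronger end of this small set.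

Compound 4 `CCCCn1cc(C(=O)NCc2ccccc2)c(=O)c2cc(F)c(N(C)Cc3ccccc3)cc21` has benzyl(methyl)amino in place of 4-carbamoylpiperidin-1-yl on an aromatic carbon, ortho to a fluoro group: benzyl(methyl)amino in place of 4-carbamoylpiperidin-1-yl on an aromatic carbon. Within the data shown here, two measured steps bear on this change, since both exchange a group at that same carbon: an at least 2.1-fold lower number from compound 1 to compound 3 (0.32 log units; beyond the scatter) and an at least 2.1-fold lower number from compound 2 to compound 3 (0.32 log units; beyond the scatter). Both end at the 4-carbamoylpiperidin-1-yl group with a lower number, whereas a step that the two limits leave unreadable from compound 1 to compound 2 gives no usable size. Compound 4 gives up that same group, and its incoming group contains an aromatic ring like the phenyl of compound 2, which reads > 100000 nM as a limit. A modest move towards higher numbers in this assay is therefore expected, namely a 2.1-fold higher number from compound 3 to compound 4 (0.33 log units; beyond the scatter), and a reading at the limit is a real possibility. The estimate for compound 4 is 100000 nM, with an expected range of 45000 nM to 220000 nM.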

Compound 4, half-maximal inhibitory concentration: 86000 nM
Compound 4: middle estimate off by 1.2-fold (0.07 log units), on the high side; measured number inside the range.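

In this assay, within the data shown here, compound 4 gives the first true number at this aromatic carbon to stand beside that of compound 3, and the step between them is a 1.8-fold higher number from compound 3 to compound 4 (0.26 log units; within the scatter). The earlier steps shown here to compound 3 suggested that 4-carbamoylpiperidin-1-yl might set it apart, but benzyl(methyl)amino, with its six-membered aromatic ring of carbon only and no hydrogen-bond donor, gives a reading that cannot be told from that of compound 3. The other new steps, an at least 1.1-fold lower number from compound 2 to compound 4 (0.06 log units; that floor lies within the scatter) and an at least 1.1-fold lower number from compound 1 to compound 4 (0.06 log units; that floor lies within the scatter), give floors only, because their starting compounds each sit at a limit: the limit of > 100000 nM in this assay, at which 2 of the 4 values shown sit.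

The compounds shown leave open whether the plain piperidin-1-yl ring, a morpholine or a carboxylic acid in place of the carbamoyl group would give a reading clearly apart from those of compound 3 and compound 4. They also leave open how the read-out responds at other places on the shared core, for instance with a longer chain in place of the butyl group or with a substituted benzyl group on the amide.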